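The source may report more compounds than this note shows. Statements on the series, on what has been measured and on what is new or still open speak of the compounds shown alone.

Compound 1 `COc1c(/C=C2/C(=O)Nc3ccccc32)c2ccccc2n1-c1ccccc1` and compound 3 `COc1c(/C=C2/C(=O)Nc3ccc(Cl)cc32)c2ccccc2n1-c1ccccc1` share one core, and compound 3 carries chloro in place of hydrogen on an aromatic carbon. In a functional assay on cells (Melanoma cell, Homo sapiens) for cytotoxicity, with a stated time of 48 h (a higher number here means a weaker inhibitor of growth, a lower number a stronger inhibitor of growth), compound 1 gives 1480 nM, while compound 3 gives 5620 nM, so that single change produced a 3.8-fold higher number from compound 1 to compound 3 (0.58 log units; beyond the scatter). Compound 2 `O=C1Nc2ccccc2/C1=C\c1c(Cl)n(CCCc2ccccc2)c2ccccc12` is built on another core, and the difference between the two cores is not broken down here. In this assay compound 2 gives 13800 nM, the highest of the three numbers. Compound 4 `O=C1Nc2ccc(Cl)cc2/C1=C\c1c(Cl)n(CCCc2ccccc2)c2ccccc12` is derived from compound 2 by chloro in place of hydrogen on an aromatic carbon, the same kind of change as from compound 1 to compound 3. Because the earlier change gave a 3.8-fold higher number from compound 1 to compound 3 (0.58 log units; beyond the scatter), a step in the same direction is expected for compound 4, with an estimated size of a 2.9-fold higher number from compound 2 to compound 4 (0.46 log units; beyond the scatter). Compound 4 is accordingly estimated at 40000 nM in this assay, expected to fall between 15000 nM and 120000 nM.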

Compound 4, concentration for 50% growth inhibition: 2040 nM
Compound 4: the middle estimate sits 20-fold (1.29 log units) above what was measured, and the stated range ends above it.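

In this assay, chloro in place of hydrogen on an aromatic carbon gave a 6.8-fold lower number from compound 2 to compound 4 (0.83 log units; beyond the scatter). Set beside the earlier step, the same change did not carry over from one core to the other, and its direction reversed: the same change on two cores in this assay, a 3.8-fold higher number (0.58 log units; beyond the scatter) from compound 1 to compound 3 and a 6.8-fold lower number (0.83 log units; beyond the scatter) from compound 2 to compound 4, 26-fold (1.41 log units) apart, beyond the scatter of two such steps. This shows that the outcome of this change depends on the core among these four compounds, but it does not show which part of the difference between the cores is responsible, and two pairs give no rule for a further core.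

The compounds shown leave open whether fluoro or a nitrile on that same aromatic carbon would split between the two cores in the same way. They also leave open whether an amine at the end of the chain of compound 2 would alter the picture.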